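The compounds below may be only part of what the source reports. "The series", "measured", "known", "first", "only" and "open" are said of these compounds alone.

Compound 1 `c1ccc(-c2cn3ccnc3c(-c3ccc4ncn(C5CCCCC5)c4c3)n2)cc1`: 16.5%
Compound 2 `COc1ccc(-c2cn3ccnc3c(-c3ccc4ncn(C5CCCCC5)c4c3)n2)cc1`: 94.3%
Compound 3 `CC(=O)c1ccc(-c2cn3ccnc3c(-c3ccc4ncn(C5CCCCC5)c4c3)n2)cc1`: 0.58%

In a functional assay on SK-MEL-2 cells (Homo sapiens) for inhibition, read by sulforhodamine B assay, with a stated time of 48 h, tested at 10 uM (on this read-out higher numbers stand for more inhibition at the one concentration tested (going by the name of the read-out) and lower numbers for less inhibition), compound 2 stands highest of the three, with a number 77.8 percentage points higher from compound 1 to compound 2 (beyond the scatter) and a number 93.7 percentage points lower from compound 2 to compound 3 (beyond the scatter) both beyond the scatter. Compound 4 `Fc1ccccc1-c1cn2ccnc2c(-c2ccc3ncn(C4CCCCC4)c3c2)n1` has not yet been measured; it differs from compound 2 by 2-fluorophenyl in place of 4-methoxyphenyl on an aromatic carbon. Within the data shown here, no measured step covers this exact change. The nearest guide is the reverse of a number 77.8 percentage points higher from compound 1 to compound 2 (beyond the scatter), which shows how much was lost when the methoxy group was absent, and a number 15.9 percentage points lower from compound 1 to compound 3 (beyond the scatter), which shows a further fall with acetyl. A large downward step is therefore expected: a number 74.3 percentage points lower from compound 2 to compound 4 (beyond the scatter). Compound 4 is expected to give 20%, within a range from 0% to 55%.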

Compound 4, a percentage reported as inhibition, at one concentration (the size of the read-out at that concentration, not a potency): 10.5%
Compound 4: middle estimate off by 9.5 percentage points, on the high side; the range from low to high includes it.
By their numbers in this assay, from the lowest: compounds 3, 4 and 1 (each within the scatter of the next, the first and the last beyond it); then compound 2.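

In this assay, 2-fluorophenyl at this position does not keep the high reading of the 4-methoxyphenyl group (a number 83.8 percentage points lower from compound 2 to compound 4 (beyond the scatter)). Fluoro in place of hydrogen leaves the compound within the scatter of the unsubstituted phenyl (a number 6 percentage points lower from compound 1 to compound 4 (within the scatter)), and 2-fluorophenyl cannot be told apart from 4-acetylphenyl (a number 9.9 percentage points higher from compound 3 to compound 4 (within the scatter)), so among these four compounds only compound 2 stands apart. No measurement given here explains this.

From the compounds shown here alone, whether the high reading is particular to methoxy stays open: an amine, a hydroxyl or a longer ether such as ethoxy could test this. A single concentration also leaves the potency of compound 2 unknown.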